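The source may hold more compounds than are shown below. What is called first, only, known or untested is meant among the compounds shown, and "the series" means these compounds.

Working notes on the series. Compound 1 `COc1ccc(Nc2nc(Oc3cccc(NC(=O)/C=C/C(C)C)c3)c3sccc3n2)cc1` and compound 2 `CC(C)=CC(=O)Nc1cccc(Oc2nc(Nc3cccc(C#N)c3)nc3ccsc23)c1` share one core and have both been run in a functional assay on A549 cells (Homo sapiens) for inhibition, read by MTT assay, with a stated time of 72 h; a higher number here means a weaker inhibitor, a lower number a stronger inhibitor. In this assay compound 1 gives 37900 nM, and compound 2 gives 16900 nM. For the measured compounds named here, compound 2 stands at the lowest of the two numbers so far, with compound 1 beyond the usual scatter from it; no single-point step between these two is computed, so their values are simply read side by side.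

The next compound is compound 3 `CC(C)/C=C/C(=O)Nc1cccc(Oc2nc(Nc3cccc(C#N)c3)nc3ccsc23)c1`, which differs from compound 2 in one place: 3-methylbut-1-en-1-yl in place of 2-methylprop-1-en-1-yl on a carbonyl carbon. Going by the values given here, for this change no measured pair exists, so the expectation rests on the two numbers above. In this assay compound 3 is expected to move by about a 1.2-fold higher number from compound 2 to compound 3 (0.07 log units; within the scatter) from compound 2, a step not beyond the scatter in either direction. Compound 3 is thus estimated at 20000 nM, with a range from 8000 nM to 50000 nM.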

Compound 3, half-maximal inhibitory concentration: 19000 nM
For compound 3 the middle estimate is 1.1-fold (0.02 log units) above the measured one; low and high end bracket the measured number.
By their numbers in this assay, from the lowest: compounds 2, 3 and 1 (each within the scatter of the next, the first and the last beyond it).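

In this assay, 3-methylbut-1-en-1-yl in place of 2-methylprop-1-en-1-yl on a carbonyl carbon, whose other neighbour is an amide-type nitrogen, gives a 1.1-fold higher number from compound 2 to compound 3 (0.05 log units; within the scatter), so this position tolerates the exchange of one alkenyl chain for the other without a change that can be told from the scatter. For the compounds shown here, compound 3 also gives the first single-place reading at the nitrogen on an aromatic ring: 3-cyanophenyl in place of 4-methoxyphenyl gives a 2.0-fold lower number from compound 1 to compound 3 (0.30 log units; within the scatter), which likewise stays within the scatter. Nothing available explains either step.

Going by these compounds, whether a longer chain, a saturated chain such as isobutyl, or a chain ending in an amine or a carboxylic acid on the same carbonyl would move the number beyond the scatter remains open. Also open, on these data alone, is how a halogen or an amide on that phenyl ring would read.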